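The source may hold more compounds than are shown below. What is called first, only, known or untested is meant among the compounds shown, and "the series" means these compounds.

Measured compounds in an assay on cells for agonist activity at probable G-protein coupled receptor 34 (Mus musculus), with a stated time of 1 h; a lower number here means a smaller maximal response, a higher number a larger maximal response:
- compound 1 `N[C@@H](COP(=O)(O)OCCCOC(=O)CCc1ccccc1OCCCCOc1ccccc1)C(=O)O`: 6.1%
- compound 2 `N[C@@H](COP(=O)(O)OCCCOC(=O)CCc1ccccc1OCCCCCCOc1ccccc1)C(=O)O`: 20.7%
- compound 3 `Cc1cccc(Oc2cccc(COc3ccccc3CCC(=O)OCCCOP(=O)(O)OC[C@H](N)C(=O)O)c2)c1`: 21.3%

Compound 3 holds the highest of the three numbers in this assay. Its gap to compound 2 is within the scatter, so no order between the two can be read; its gap to compound 1 is beyond the scatter. Among the measured compounds shown here, the one step recorded within the measured set, a number 14.6 percentage points higher from compound 1 to compound 2 (beyond the scatter), concerns the chain and not the outer aromatic ring.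

Compound 4 `N[C@@H](COP(=O)(O)OCCCOC(=O)CCc1ccccc1OCc1cccc(Oc2ccc(F)cc2)c1)C(=O)O` differs from compound 3 in one place: 4-fluorophenyl in place of 3-methylphenyl on an oxygen on an aromatic ring. For the measured compounds named here, no measured pair changes the outer aromatic ring, so nothing measured bears directly on this step, and the step from compound 1 to compound 2 gives no guide to it. The expectation for compound 4 is therefore a number close to that of compound 3, with a step of a number 2.3 percentage points lower from compound 3 to compound 4 (within the scatter) that is estimated to stay within the scatter. Compound 4 is estimated at 19% in this assay, with a range from 8% to 32%.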

Compound 4, largest response reached (Emax), in percent of the reference or control that the assay uses: 18.7%
For compound 4 the middle estimate is 0.3 percentage points above the measured one; measured number inside the range.
By their numbers in this assay, from the lowest: compound 1; then compounds 4, 2 and 3 (each within the scatter of the next).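

In this assay, among the compounds shown here, the exchange of 3-methylphenoxy for 4-fluorophenoxy gives a number 2.6 percentage points lower from compound 3 to compound 4 (within the scatter) and is the first measured change at this outer aromatic ring. On an oxygen on an aromatic ring, 4-fluorophenyl thus takes the place of 3-methylphenyl with no readable change in maximal response, so this pair shows a tolerated exchange, in contrast with the chain step a number 14.6 percentage points higher from compound 1 to compound 2 (beyond the scatter) that lies beyond the scatter. No measured property is available to account for this result.

Going by these compounds, whether a nitrile, a trifluoromethyl group or an amine on this outer ring would shift the maximal response beyond the scatter remains open. Also open, on these data alone, is whether a carboxylic acid at this place would read differently from the 4-fluorophenyl of compound 4 in this assay as well.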